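The source may hold more compounds than are shown below. What is called first, only, known or untested is meant among the compounds shown, and "the series" means these compounds.

Measured compounds in a functional assay on the whole organism (strain albino) for inhibition, with Rattus norvegicus as the target, read by paw edema, with stated times of 30 min and 5 h, at a dose of 100 mg/kg by the oral route; on this read-out higher numbers stand for more inhibition at the one dose given (going by the name of the read-out) and lower numbers for less inhibition:
- compound 1, `O=C(CO[N+](=O)[O-])Nc1ccc(C(=O)/C=C/c2ccc(Cl)cc2)cc1`, gives 60%
- compound 2, `CC(Br)C(=O)Nc1ccc(C(=O)/C=C/c2ccc(Cl)cc2)cc1`, gives 50%
- compound 3, `O=C(COCc1c(-c2ccccc2)no[n+]1[O-])Nc1ccc(C(=O)/C=C/c2ccc(Cl)cc2)cc1`, gives 62%

All three share one core and differ only in the group carried on the amide carbonyl. For the measured compounds named here, the one step that can be read directly is a number 10 percentage points lower from compound 1 to compound 2 (within the scatter), so the exchange on the carbonyl carbon does not move the paw-edema read-out beyond the usual scatter. Compound 3 holds the highest of the three numbers; compound 1 sits within the scatter of it, while compound 2 lies beyond the scatter below it, so the number of compound 3 can be called higher than that of compound 2 only, and level with that of compound 1.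

Compound 4, `COc1ccc(/C=C/C(=O)c2ccc(NC(=O)COCc3c(-c4ccccc4)no[n+]3[O-])cc2)cc1`, keeps the amide side chain of compound 3 and changes the far end of the molecule instead: methoxy in place of chloro on an aromatic carbon. Going by the values given here, none of the measured steps touches this aromatic carbon, so no measured comparison bears on the change; the measured steps all concern the carbonyl substituent and were small. In the absence of any guide, compound 4 is expected to stay close to compound 3, with a number 2 percentage points lower from compound 3 to compound 4 (within the scatter) read as no step beyond the scatter. Compound 4 is therefore estimated at 60% in this assay, between 46% and 72%.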

Compound 4, a percentage reported as inhibition, in the whole organism at one dose (the size of the read-out at that dose, not a potency): 49%
The estimate for compound 4 lay 11 percentage points above the measured number; low and high end bracket the measured number.
By their numbers in this assay, from the lowest: compounds 4, 2, 1 and 3 (each within the scatter of the next, the first and the last beyond it).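

In this assay, methoxy in place of chloro on an aromatic carbon para to a large group gives a number 13 percentage points lower from compound 3 to compound 4 (beyond the scatter), which shows that the paw-edema read-out responds to a change at this far end of the molecule, with the amide side chain held fixed. The only earlier step, a number 10 percentage points lower from compound 1 to compound 2 (within the scatter), concerned the group on the amide carbonyl and stayed within the scatter, so this is the first step shown to lie beyond it, and it comes from a position the earlier compounds left untouched. Nothing shown accounts for why methoxy gives the lower number here.

From the compounds shown here alone, this single pair rests on one side chain, so it remains open whether the same exchange would give a similar step with the (nitrooxy)methyl group of compound 1 or the 1-bromoethyl group of compound 2. It also leaves open how other groups at this aromatic carbon, such as fluoro, methyl, hydroxyl or an amine, would stand relative to chloro and methoxy at this single dose.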